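Urea to amide on the aryl pyrazole series

This account rests on a few compounds, and the source may have more. Where it says the series, first, only, none or still open, it means among the compounds named here.

Measured so far:
compound 1, `COc1cc(-c2nn(-c3cccc(NC(=O)c4cccc(C(F)(F)F)c4)c3)cc2-c2ccncc2)ccc1Cl`, 4560 nM
compound 2, `COc1cc(-c2nn(-c3cccc(NC(=O)Nc4ccc(Cl)c(Cl)c4)c3)cc2-c2ccncc2)ccc1Cl`, 2270 nM
compound 3, `COc1cc(-c2nn(-c3cccc(NC(=O)Nc4cccc(C(F)(F)F)c4)c3)cc2-c2ccncc2)ccc1Cl`, 2160 nM

In a functional assay on MDA-MB-468 cells (Homo sapiens) for inhibition, read by sulforhodamine B assay, with a stated time of 48 h (on this read-out lower numbers stand for stronger inhibition of growth and higher numbers for weaker inhibition of growth), compound 3 gives the lowest of the three numbers; compound 2 sits within the scatter of it, while compound 1 lies beyond it, as the step of a 2.1-fold lower number from compound 1 to compound 3 (0.32 log units; beyond the scatter) shows. Compound 4, `COc1cc(-c2nn(-c3cccc(NC(=O)c4ccc(Cl)c(C(F)(F)F)c4)c3)cc2-c2ccncc2)ccc1Cl`, has not yet been measured. It differs from compound 3 in one place: 4-chloro-3-(trifluoromethyl)phenyl in place of (3-(trifluoromethyl)phenyl)amino on a carbonyl carbon. For the measured compounds named here, two measured steps bear on this. The step of a 2.1-fold lower number from compound 1 to compound 3 (0.32 log units; beyond the scatter) shows what the urea-to-amide exchange did with the same trifluoromethyl-bearing ring, and a 2.0-fold lower number from compound 1 to compound 2 (0.30 log units; within the scatter) shows a similar size for the urea carrying the dichlorophenyl ring. The step of a 1.1-fold lower number from compound 2 to compound 3 (0.02 log units; within the scatter) shows that swapping chloro for trifluoromethyl substitution on the urea ring changed little. Compound 4 is therefore expected to show a step of a 1.9-fold higher number from compound 3 to compound 4 (0.29 log units; within the scatter), a higher number than compound 3, roughly back to where compound 1 stands. The estimate for compound 4 is 4200 nM, with a range from 2000 nM to 9000 nM.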

Compound 4, concentration for total growth inhibition: > 32500 nM
Compound 4: a limit, no number; the forecaster's own chance of this, stated with the estimate: 5%; at least 7.7-fold (0.88 log units) between middle value and limit.
By their numbers in this assay, from the lowest: compounds 3, 2 and 1 (each within the scatter of the next, the first and the last beyond it). At a limit, above all of these: compound 4.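

The reading for compound 4 is a limit of the assay and not a number: the limit of > 32500 nM in this assay, at which 1 of the 4 values shown sits. Even so, the step of an at least 7.1-fold higher number from compound 1 to compound 4 (0.85 log units; beyond the scatter) shows that a single chloro in place of hydrogen on an aromatic carbon of the amide ring can count for more than any change among the earlier compounds, none of whose steps went past modest. The choice between amide and urea also weighs far more once the ring carries this chloro, as the steps of an at least 15-fold higher number from compound 3 to compound 4 (1.17 log units; beyond the scatter) and an at least 14-fold higher number from compound 2 to compound 4 (1.15 log units; beyond the scatter) are both large.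

From the compounds shown here alone, how far compound 4 lies past its limit stays open, and with it the true size of these steps. Also open, going by these compounds, is whether an amide with methoxy or an amine in place of the chloro would keep the growth inhibition of compound 1.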